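A few compounds are considered here, and "the series" means these few. Any claim that something is new, unique, unknown or untested is made for them only; others in the source may bear on it.

Measured compounds:
Compound 1 `O=C(Nc1ccc(Cl)cc1CN1C(=O)c2ccccc2C1=O)c1ccccc1C(F)(F)F`: in an assay on CHO cells for positive allosteric modulation of metabotropic glutamate receptor 5 (Rattus norvegicus), read by FLIPR (a higher number here means that more compound is needed for the effect, a lower number that less compound is needed), compound 1 gives < 1000 nM, which is a limit of the assay.
Compound 2 `O=C(Nc1ccc(Cl)cc1CN1C(=O)c2ccccc2C1=O)c1cncs1`: in this assay compound 2 gives < 1000 nM, also a limit.
Compound 3 `COc1ccccc1C(=O)Nc1ccc(Cl)cc1CN1C(=O)c2ccccc2C1=O`: in this assay compound 3 gives < 1000 nM, again a limit.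

Compound 3 thus stands at the limit (the limit of < 1000 nM in this assay, at which 3 of the 3 values shown sit), so its place within the series cannot be read. Compound 4 `O=C(Nc1ccc(Cl)cc1CN1C(=O)c2ccccc2C1=O)c1cccnn1` differs from compound 3 by pyridazin-3-yl in place of 2-methoxyphenyl on a carbonyl carbon. Within the data shown here, the steps that bear on this change are a step that the two limits leave unreadable from compound 1 to compound 2, a step that the two limits leave unreadable from compound 1 to compound 3 and a step that the two limits leave unreadable from compound 2 to compound 3; none has a readable size. Every exchange of the group on the carbonyl carbon has so far left the value at the limit, and compound 4 is expected to do the same. The expected step is a step that the limit leaves unreadable from compound 3 to compound 4, within the scatter. Compound 4 is estimated at 500 nM, between 100 nM and 2500 nM, with a fair chance that only a limit is reported.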

Compound 4, half-maximal effective concentration: < 1000 nM
Compound 4 gave a limit, no number; the forecaster's own chance of this, stated with the estimate: 55%; the middle value lies beyond the limit too.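

No step from compound 4 to compound 1, compound 2 or compound 3 can be read in this assay, since all four compounds sit at a limit: the limit of < 1000 nM in this assay, at which 4 of the 4 values shown sit.

The compounds shown leave open how far these four compounds actually differ from one another.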